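Working notes: 3-chlorophenyl replacing 4-methoxyphenyl

A few compounds are considered here, and "the series" means these few. Any claim that something is new, unique, unknown or untested is made for them only; others in the source may bear on it.

Measured so far in a functional assay on PC-3 cells (Homo sapiens) for inhibition, read by sulforhodamine B assay; on this read-out higher numbers stand for weaker inhibition of growth and lower numbers for stronger inhibition of growth:
- compound 1 `Clc1cccc(-c2ccc(-c3ccc(-c4nc5ccccc5[nH]4)cc3)cc2)c1`: 33700 nM
- compound 2 `Oc1cccc2[nH]c(-c3ccc(-c4ccc(-c5ccc(F)cc5)cc4)cc3)nc12`: 15300 nM
- compound 3 `COc1ccc(-c2ccc(-c3ccc(-c4nc5c(O)cccc5[nH]4)cc3)cc2)cc1`: 6610 nM

Compound 3 has the lowest number of the three. Its gaps to the other two values both lie beyond the scatter, and the nearer of them is to compound 2.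

The next compound is compound 4 `Oc1cccc2[nH]c(-c3ccc(-c4ccc(-c5cccc(Cl)c5)cc4)cc3)nc12`, with 3-chlorophenyl in place of 4-methoxyphenyl on an aromatic carbon.

Among the measured compounds shown here, one measured step bears directly on this change, as it alters the same outer aryl group on the same core: a 2.3-fold lower number from compound 2 to compound 3 (0.36 log units; beyond the scatter). That step is modest but beyond the scatter, and it leaves compound 3 with the lower number. For the measured compounds named here, no measured step isolates 3-chlorophenyl on this core. Going by the values given here, compound 1 also carries 3-chlorophenyl, on a core of its own, and in this assay compound 1 gives 33700 nM, the highest number so far.

Giving up the 4-methoxyphenyl group is therefore expected to raise the number by a modest amount, similar in size to the measured step. The estimated step is a 2.3-fold higher number from compound 3 to compound 4 (0.36 log units; beyond the scatter). For compound 4 the expected value is 15000 nM, with an estimated range of 6000 nM to 35000 nM.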

Compound 4, concentration for 50% growth inhibition: 2560 nM
Compound 4: middle estimate off by 5.9-fold (0.77 log units), on the high side; measured number outside the range, below it.
By their numbers in this assay, from the lowest: compound 4; then compound 3; then compound 2; then compound 1.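

In this assay, among the compounds shown here, the outer aryl group on the shared core of compounds 2, 3 and 4 can change without a loss of growth inhibition: 3-chlorophenyl gives a 2.6-fold lower number from compound 3 to compound 4 (0.41 log units; beyond the scatter) and a 6.0-fold lower number from compound 2 to compound 4 (0.78 log units; beyond the scatter), the lowest number so far. The high number of compound 1 therefore cannot be read as a penalty of 3-chlorophenyl itself, since with that group held constant, hydroxy in place of hydrogen on an aromatic carbon gives a 13-fold lower number from compound 1 to compound 4 (1.12 log units; beyond the scatter), the largest step yet seen in this series. On the shared core the three outer groups now rank 3-chlorophenyl, 4-methoxyphenyl, 4-fluorophenyl, from lowest number to highest, with each gap beyond the scatter.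

The data shown offer no explanation for this order or for the size of the hydroxy step. Still open, on these data alone, are how far the number moves with an amine or a carboxylic acid on the outer ring, and whether hydroxy in place of hydrogen gives a step of similar size with 4-methoxyphenyl or 4-fluorophenyl as the outer group.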